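Compound 3 to compound 4: methylamino to ethylamino

The source may hold more compounds than are shown below. What is called first, only, known or untested is meant among the compounds shown, and "the series" means these compounds.

In a functional assay on NTUB1 cells (Homo sapiens) for cytotoxicity, read by MTT assay, with a stated time of 72 h (on this read-out lower numbers stand for stronger inhibition and higher numbers for weaker inhibition), compound 1 `COC(=O)c1ccc(/C=C/C(=O)c2cc(OC)ccc2OC)cc1` gives 3510 nM, compound 2 `COc1ccc(OC)c(C(=O)/C=C/c2ccc(C(=O)OCC=C(C)C)cc2)c1` gives 13400 nM and compound 3 `CNC(=O)c1ccc(/C=C/C(=O)c2cc(OC)ccc2OC)cc1` gives 2200 nM. Compound 3 shares the low end of these numbers with compound 1: the step of a 1.6-fold lower number from compound 1 to compound 3 (0.20 log units; within the scatter) separates nothing, whereas the step of a 6.1-fold lower number from compound 2 to compound 3 (0.78 log units; beyond the scatter) is a modest but real gap.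

Compound 4 `CCNC(=O)c1ccc(/C=C/C(=O)c2cc(OC)ccc2OC)cc1` carries methyl in place of hydrogen on a saturated chain carbon bound to an amide-type nitrogen, so that methylamino becomes ethylamino: methyl in place of hydrogen on a saturated chain carbon bound to an amide-type nitrogen.

Among the measured compounds shown here, no measured step makes this exact change. For the measured compounds named here, the closest precedent is the lengthening of the ester chain from compound 1 to compound 2, the step of a 3.8-fold higher number from compound 1 to compound 2 (0.58 log units; beyond the scatter), which added a larger group and was modest in size. A single methyl on the amide chain is therefore expected to move the number little, if at all. The expected step is a 1.3-fold higher number from compound 3 to compound 4 (0.10 log units; within the scatter), a slight rise that should stay within the scatter. For compound 4 the estimated value is 2800 nM, with an expected range of 1200 nM to 6500 nM.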

Compound 4, half-maximal inhibitory concentration: 3760 nM
Estimate against measurement, compound 4: 1.3-fold (0.13 log units) below; the measured number falls inside the stated range.
By their numbers in this assay, from the lowest: compounds 3, 1 and 4 (each within the scatter of the next); then compound 2.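

In this assay, adding methyl on the saturated chain carbon bound to the amide-type nitrogen leaves the result within the scatter (a 1.7-fold higher number from compound 3 to compound 4 (0.23 log units; within the scatter)), so ethylamino and methylamino cannot be told apart at this position. Ethylamino also stands level with methoxy on the carbonyl carbon (a 1.1-fold higher number from compound 1 to compound 4 (0.03 log units; within the scatter)), while the gap to (3-methylbut-2-en-1-yl)oxy remains beyond the scatter (a 3.6-fold lower number from compound 2 to compound 4 (0.55 log units; beyond the scatter)), so a second amide now separates from compound 2 but not from compound 1. Nothing on hand explains these steps.

Open, from the compounds shown here alone, is whether a longer chain on the amide nitrogen, such as propylamino or butylamino, stays level with these two amides. Also open, going by these compounds, is whether (3-methylbut-2-en-1-yl)amino on the carbonyl carbon would fall with the amides or with compound 2.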